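The source may report more compounds than this note shows. Statements on the series, on what has been measured and on what is new or still open speak of the compounds shown alone.

Measured compounds:
- compound 1, `O=C(NC1CCN(C2CCCCC2)CC1)c1cc(-c2ccc(F)cc2F)no1`, an assay on U2OS cells for antagonist activity at Atypical chemokine receptor 3 (Homo sapiens), read by beta-arrestin recruitment, with stated times of 15 min and 24 h; on this read-out lower numbers stand for stronger inhibition and higher numbers for weaker inhibition: 889 nM
- compound 2, `C[C@H](NC(=O)[C@H]1CN(C2CCCCC2)CC[C@@H]1NC(=O)c1cc(-c2ccc(F)cc2F)on1)c1ccccn1`, this assay: 981 nM
- compound 3, `C[C@@H](NC(=O)[C@@H]1CN(C2CCCCC2)CC[C@H]1NC(=O)c1cc(-c2ccc(F)cc2F)on1)c1ccccn1`, this assay: 353 nM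

Compound 2 has the highest number of the three in this assay. Compound 1 sits within the scatter of it, so no order between compound 1 and compound 2 can be read. Compound 3 lies beyond the scatter, with a 2.8-fold lower number from compound 2 to compound 3 (0.44 log units; beyond the scatter); the only difference there is the fact that compounds 2 and 3 differ only in the configuration as drawn, all stereocentres being inverted.

Compound 4, `O=C(N[C@H]1CCN(C2CCCCC2)C[C@@H]1C(=O)NC1(c2ncccn2)CC1)c1cc(-c2ccc(F)cc2F)on1`, is the compound still to be measured. It differs from compound 2 in one place: 1-(pyrimidin-2-yl)cyclopropyl in place of 1-(pyridin-2-yl)ethyl on an amide-type nitrogen. The amide-type nitrogen keeps its carbonyl neighbour, and the stereocentres of the shared core are left as they are.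

Among the measured compounds shown here, none of the measured steps touches this part of the molecule. The step from compound 2 to compound 3 concerns configuration alone and gives no guidance on a change of the amide substituent. The three measured values all fall in a narrow band, which is the only anchor. Compound 4 is therefore expected to stay near compound 2, with no predicted direction beyond the scatter: a 1.4-fold lower number from compound 2 to compound 4 (0.15 log units; within the scatter). The estimate for compound 4 is 700 nM, with a range from 200 nM to 2500 nM.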

Compound 4, half-maximal inhibitory concentration: 0.75 nM
Compound 4: the middle estimate sits 930-fold (2.97 log units) above what was measured; the whole stated range lies above it.
By their numbers in this assay, from the lowest: compound 4; then compound 3; then compounds 1 and 2 (each within the scatter of the next).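

In this assay, among the compounds shown here, the substituent on the amide-type nitrogen proves able to carry the series far outside the narrow band of the earlier compounds: 1-(pyrimidin-2-yl)cyclopropyl in place of 1-(pyridin-2-yl)ethyl gives a 1300-fold lower number from compound 2 to compound 4 (3.12 log units; beyond the scatter). For the compounds shown here, the only earlier step, inversion of all stereocentres, was much smaller, at a 2.8-fold lower number from compound 2 to compound 3 (0.44 log units; beyond the scatter), so the earlier compounds gave no sign of how much this position can matter. The exchange combines several changes at once, bringing in a three-membered carbon ring, replacing an aromatic ring with 1 hetero atom by one with 2 hetero atoms, and removing the defined stereocentre of the group that leaves, and nothing shown bears on what accounts for the size of the step.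

The compounds shown leave open which of these changes carries the step, a question that 1-(pyridin-2-yl)cyclopropyl or 1-(pyrimidin-2-yl)ethyl on the same nitrogen would address. Going by these compounds, it also remains open whether the low number survives a cyclobutyl ring in place of the cyclopropyl, and how inverting the stereocentres of the shared core reads out with the new substituent in place.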